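From furan-2-yl to 2-methoxyphenyl in compound 3

The source may hold more compounds than are shown below. What is called first, only, known or untested is meant among the compounds shown, and "the series" means these compounds.

In a functional assay on PC-3 cells (Homo sapiens) for inhibition, read by sulforhodamine B assay, with a stated time of 48 h, tested at 50 uM (a higher number here means more inhibition of growth at the concentration tested, a lower number less inhibition of growth), compound 3 `COc1cc(/C=C/C(=O)/C=C/c2ccco2)ccc1OCc1cn(CCCOc2cc(=O)oc3ccccc23)nn1` gives "not active" (no number reported) and so has no single number to its name. Compound 2 `COc1ccc(/C=C/C(=O)/C=C/c2ccc(OCc3cn(CCCCCOc4cc(=O)oc5ccccc45)nn3)c(OC)c2)cc1OC` carries the same report of "not active" (no number reported) in that test. Among the measured compounds shown here, the only number so far belongs to compound 1 `COc1cc(/C=C/C(=O)/C=C/c2cccc3ccccc23)ccc1OCc1cn(CCCOc2cc(=O)oc3ccccc23)nn1` at 8% under the same conditions.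

Compound 4 `COc1ccccc1/C=C/C(=O)/C=C/c1ccc(OCc2cn(CCCOc3cc(=O)oc4ccccc34)nn2)c(OC)c1` differs from compound 3 on a double-bonded chain carbon bound to a double-bonded chain carbon: 2-methoxyphenyl in place of furan-2-yl on a double-bonded chain carbon bound to a double-bonded chain carbon with 2-methoxyphenyl in place of furan-2-yl. For the measured compounds named here, no measured step covers this change. In this assay only a small rise, within the scatter, is expected because compound 1 gives 8% with its own group at that place. For compound 4 the estimate is 8% with an expected range from 0% to 25% in growth inhibition.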

Compound 4, percent growth inhibition at one concentration: "not active" (no number reported)
Nothing numeric was reported for compound 4; there is nothing to compare the estimate with.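

In this assay compound 3 and compound 4 are both reported as not active, without a number, so no step can be read between them. No measurement shown offers an explanation. The compounds shown leave open whether the group at this place affects growth inhibition at all.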